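The source may hold more compounds than are shown below. What is called first, only, known or untested is meant among the compounds shown, and "the series" means these compounds.

Compound 1 `COc1cc(/C=C/C(=O)/C=C/c2ccccc2)ccc1OCc1cn(CCCOc2cc(=O)oc3ccccc23)nn1` was tested in a functional assay on COLO 205 cells (Homo sapiens) for inhibition, read by sulforhodamine B assay, with a stated time of 48 h, tested at 50 uM (on this read-out higher numbers stand for more inhibition of growth at the one concentration tested and lower numbers for less inhibition of growth), where compound 1 gives 43%. Compound 2 `COc1cc(/C=C/C(=O)/C=C/c2ccco2)ccc1OCc1cn(CCCCOc2cc(=O)oc3ccccc23)nn1` gives 43% in this assay, level with compound 1 at the digits shown and within the scatter, so the two together stand as the lowest of the three numbers. Compound 3 `COc1ccc(/C=C/C(=O)/C=C/c2ccc(OCc3cn(CCOc4cc(=O)oc5ccccc45)nn3)c(OC)c2)cc1` gives 68% in this assay, a higher number than that of compound 1, a gap beyond the scatter.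

Compound 4 `COc1ccc(/C=C/C(=O)/C=C/c2ccc(OCc3cn(CCCOc4cc(=O)oc5ccccc45)nn3)c(OC)c2)cc1` is the compound not yet measured. It differs from compound 1 by methoxy in place of hydrogen on an aromatic carbon; the change sits on an aromatic carbon of a six-membered aromatic ring of carbon only, para to a large group. Among the measured compounds shown here, no measured pair shows this single change on its own, so there is nothing to say of its size from direct comparison.

Because compound 3 gives 68%, and compound 1 gives 43%, compound 4 is expected to rise by a number 15 percentage points higher from compound 1 to compound 4 (beyond the scatter), a step beyond the scatter in this assay. Compound 4 is therefore estimated at 58%, between 42% and 74%.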

Compound 4, percent growth inhibition at one concentration: 53%
The estimate for compound 4 lay 5 percentage points above the measured number; the range from low to high includes it.
By their numbers in this assay, from the lowest: compounds 1, 2 and 4 (each within the scatter of the next); then compound 3.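

In this assay, among the compounds shown here, methoxy in place of hydrogen on an aromatic carbon, para to a large group, gives a number 10 percentage points higher from compound 1 to compound 4 (within the scatter), the first reading of this single change on its own. That step lies within the scatter, so the pair shows that phenyl and 4-methoxyphenyl cannot be told apart at this position in this assay, and the difference of this change is not large enough here to stand out from repeat measurements. Nothing available explains the step or says what the methoxy group does at this position.

Going by these compounds, whether another group at this position, such as an amine, a carboxylic acid or a chlorine atom, would give a step beyond the scatter stays open. Also open, on these data alone, is whether methoxy would give the same result on a compound with a longer chain.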